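The source may report more compounds than this note shows. Statements on the series, on what has been measured and on what is new or still open speak of the compounds shown alone.

Measured in a functional assay on A-375 cells (Homo sapiens) for antiproliferative activity; on this read-out lower numbers stand for stronger inhibition and higher numbers for weaker inhibition:
- Compound 1 `O=C(Nc1ccc(-c2cscn2)cc1)C1CCCN(S(=O)(=O)c2ccc(F)c(F)c2)C1`: > 20000 nM (a limit of the assay, not a number)
- Compound 2 `O=C(Nc1ccc(-c2cscn2)cc1)[C@H]1CCCN(Cc2ccc(F)c(F)c2)C1`: 190 nM
- Compound 3 `O=C(Nc1ccc(-c2cscn2)cc1)C1CCCN(Cc2cccc(F)c2)C1`: 2450 nM

For the measured compounds named here, only two of these readings are true numbers. Of the two, compound 3 at 2450 nM is the higher, and compound 2 at 190 nM lies lower by more than the usual scatter.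

The next step leads to compound 4 `O=C(Nc1ccc(-c2cscn2)cc1)C1CCCN(Cc2ccc(Cl)c(Cl)c2)C1`, which has 3,4-dichlorophenyl in place of 3-fluorophenyl on a saturated chain carbon bound to an amine nitrogen in a ring.

A move to a lower number in this assay, beyond the scatter, is expected. This expectation rests on compound 2 at 190 nM, whose benzyl ring is substituted like the entering 3,4-dichlorobenzyl group. Compound 2 has fluorine where compound 4 has chlorine, and it is drawn with defined stereochemistry, so the range is kept wide. The estimated step is a 4.9-fold lower number from compound 3 to compound 4 (0.69 log units; beyond the scatter). For compound 4 the estimated value is 500 nM, with an expected range of 120 nM to 2200 nM.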

Compound 4, half-maximal inhibitory concentration: 1730 nM
Compound 4: the middle estimate sits 3.5-fold (0.54 log units) below what was measured, and the stated range covers the measured number.
By their numbers in this assay, from the lowest: compound 2; then compounds 4 and 3 (each within the scatter of the next). At a limit, above all of these: compound 1.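

In this assay, the swap at this place, on a saturated chain carbon bound to an amine nitrogen in a ring, gives a 1.4-fold lower number from compound 3 to compound 4 (0.15 log units; within the scatter), so 3-fluorophenyl and 3,4-dichlorophenyl are not separated on this read-out. A 3,4-dichlorophenyl group at this place is therefore tolerated, but exchanging it for 3-fluorophenyl brings no measurable gain in this series. Nothing shown gives a reason for this outcome.

Compound 2 at 190 nM differs from compound 4 both in its halogen and in its drawn stereochemistry, so the compounds shown do not tell which of the two accompanies its value. Also open, on these data alone, is how a pyridine ring or a methoxy group at this place would read in this assay.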